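Cyclopropyl in place of methylsulfanyl on the shared core

A few compounds are considered here, and "the series" means these few. Any claim that something is new, unique, unknown or untested is made for them only; others in the source may bear on it.

Within the data shown here, compound 2 `CCc1nc(SC)c2n1CCN([C@@H](C(=O)NC)c1ccccc1)[C@H]2CCc1ccc(C(F)(F)F)cc1` gives 85 nM in a functional assay on CHO cells for antagonist activity at Orexin/Hypocretin receptor type 1 (Homo sapiens), read by FLIPR and calcium flux (on this read-out higher numbers stand for weaker inhibition and lower numbers for stronger inhibition), the lowest of the three numbers measured so far: compound 3 `CCc1nc(C(=O)N(C)C)c2n1CCN([C@@H](C(=O)NC)c1ccccc1)C2CCc1ccc(C(F)(F)F)cc1` gives 344 nM, and compound 1 `CCc1nc(C(F)(F)F)c2n1CCN([C@@H](C(=O)NC)c1ccccc1)[C@H]2CCc1ccc(C(F)(F)F)cc1` gives 1070 nM. The step of a 13-fold lower number from compound 1 to compound 2 (1.10 log units; beyond the scatter) shows that what this aromatic carbon carries matters strongly. Compound 4 `CCc1nc(C2CC2)c2n1CCN([C@@H](C(=O)NC)c1ccccc1)[C@H]2CCc1ccc(C(F)(F)F)cc1` is the next candidate, with cyclopropyl in place of methylsulfanyl on an aromatic carbon. Among the measured compounds shown here, only the step from compound 1 to compound 2 bears directly on this change, and it was large; the values of compound 2 and compound 3 also lie far apart for a change at the same aromatic carbon. A moderate rise is therefore expected, a 2.6-fold higher number from compound 2 to compound 4 (0.41 log units; beyond the scatter). Compound 4 is estimated at 220 nM in this assay, within the range 60 nM to 800 nM.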

Compound 4, half-maximal inhibitory concentration: 4170 nM
For compound 4 the middle estimate is 19-fold (1.28 log units) below the measured one; measured number outside the range, above it.
By their numbers in this assay, from the lowest: compound 2; then compound 3; then compound 1; then compound 4.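

On this aromatic carbon, cyclopropyl is far less well accepted than methylsulfanyl, with a 49-fold higher number from compound 2 to compound 4 (1.69 log units; beyond the scatter), and it also falls behind trifluoromethyl, with a 3.9-fold higher number from compound 1 to compound 4 (0.59 log units; beyond the scatter). Among these three groups on the same core, methylsulfanyl therefore gives the strongest inhibition and cyclopropyl the weakest, so a small carbon ring does not stand in for methylsulfanyl here. Nothing available explains this loss. On these data alone, whether ethylsulfanyl, methoxy or dimethylamino on this carbon would match compound 2 or fall away like compound 4 remains open.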